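Replacing an acetyl with a pyrrolidine amide on a piperidine

The compounds below may be only part of what the source reports. "The series", "measured", "known", "first", "only" and "open" are said of these compounds alone.

Measured compounds:
compound 1, `CC(C)n1nc(-c2ccnc3[nH]c(C4CCN(CC(=O)N(C)C)CC4)cc23)ccc1=O`, 13 uL/min
compound 2, `COc1cc(C(=O)N2CCCC2)ccc1-c1ccnc2[nH]c(C3CCOCC3)cc12`, 74 uL/min
compound 3, `CC(=O)N1CCC(c2cc3c(-c4ccc(=O)n(C(C)C)c4)ccnc3[nH]2)CC1`, < 3 uL/min

Three compounds have been run in an ADME assay on microsomes from liver (Homo sapiens) for metabolic stability; on this read-out higher numbers stand for fast clearance and lower numbers for slow clearance. Compound 2 gives 74 uL/min and compound 1 gives 13 uL/min. For compound 3 the result is only a limit of the assay, < 3 uL/min, not a number; (the limit of < 3 uL/min in this assay, at which 1 of the 3 values shown sits). Compound 3 therefore stands at the slow end of what this assay can report, with compound 1 and compound 2 showing higher readings.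

The next compound, compound 4, has the structure `CC(C)n1cc(-c2ccnc3[nH]c(C4CCN(CC(=O)N5CCCC5)CC4)cc23)ccc1=O`. It keeps the core of compound 3 and changes one group: ((pyrrolidin-1-yl)carbonyl)methyl in place of acetyl on an amine nitrogen in a ring

For the measured compounds named here, no pair of measured compounds shows this change directly. What can be compared is compound 1, which carries a related amide-bearing chain on the same ring nitrogen and gives 13 uL/min in this assay. On that basis compound 4 is expected to move above the limit seen for compound 3, a step of an at least 5.0-fold higher number from compound 3 to compound 4 (0.69 log units; beyond the scatter) that is estimated to exceed the scatter of the assay. The expected reading for compound 4 in this assay is 15 uL/min, within a range from 5 uL/min to 45 uL/min.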

Compound 4, intrinsic clearance in a liver preparation (reported as CLH), per the amount of preparation that the assay uses: 45 uL/min
Compound 4: the middle estimate sits 3.0-fold (0.48 log units) below what was measured; low and high end bracket the measured number.
By their numbers in this assay, from the lowest: compound 1; then compounds 4 and 2 (each within the scatter of the next). At a limit, below all of these: compound 3.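

In this assay, for the compounds shown here, this is the first direct view of a change on an amine nitrogen in a ring: replacing acetyl with ((pyrrolidin-1-yl)carbonyl)methyl while the rest of the molecule stays the same gives an at least 15-fold higher number from compound 3 to compound 4 (1.17 log units; beyond the scatter), a large step that shows this one position can strongly affect the reading. The true size of the step may be greater, as the reading for compound 3 is only a limit of the assay: the limit of < 3 uL/min in this assay, at which 1 of the 4 values shown sits. The counts of hydrogen-bond donors and acceptors stay the same and neither group carries a net charge, so what differs in these computed features is the larger group with its five-membered non-aromatic ring.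

This single swap alters both the chain on the nitrogen and the ring at its end, so the compounds shown cannot tell which of the two goes with the higher number. On these data alone, how a simple ethyl group, a morpholine amide or a carboxylic acid on the same nitrogen would read in this assay also remains open.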